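Cinnamamide series: a second methoxy addition on the aryl ring

The source may hold more compounds than are shown below. What is called first, only, known or untested is meant among the compounds shown, and "the series" means these compounds.

Compound 1, `COc1cccc(/C=C/C(=O)NCc2ccc(OCc3nc(C)c(C)nc3C)c(OC)c2)c1`, and compound 2, `COc1ccc(/C=C/C(=O)NCc2ccc(OCc3nc(C)c(C)nc3C)c(OC)c2)cc1OC`, share one core and differ in one place: methoxy in place of hydrogen on an aromatic carbon. In a functional assay on SH-SY5Y cells (Homo sapiens) for cytotoxicity, read by MTT assay, with stated times of 24 h and 4 h (a higher number here means that more compound is needed for the effect, a lower number that less compound is needed), compound 1 gives 4320 nM and compound 2 gives 4470 nM, so that the step of a 1.0-fold higher number from compound 1 to compound 2 (0.01 log units; within the scatter) lies within the scatter.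

Compound 3, `COc1ccc(OC)c(/C=C/C(=O)NCc2ccc(O)c(OC)c2)c1`, stands on a different core; the difference between the two cores is not broken down here. In this assay compound 3 gives 9500 nM, the highest number of the three, beyond the scatter from both compound 1 and compound 2.

Compound 4, `COc1cc(CNC(=O)/C=C/c2cc(OC)c(OC)cc2OC)ccc1O`, is not yet measured. It differs from compound 3 in one place: methoxy in place of hydrogen on an aromatic carbon. The entering group is the same as from compound 1 to compound 2, but the surroundings differ: in compound 4 the new methoxy is also meta to a methoxy group, which is not so in compound 2, so this is the same kind of change rather than the same change.

Going by the values given here, the only precedent, the step from compound 1 to compound 2, barely moved the number, and that is the sole basis here. The step from compound 3 to compound 4 in this assay is therefore expected to be about a 1.1-fold lower number from compound 3 to compound 4 (0.02 log units; within the scatter), with the wider range allowing for the different core and surroundings. Compound 4 is estimated at 9000 nM, between 4500 nM and 18000 nM.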

Compound 4, half-maximal effective concentration: 2410 nM
The estimate for compound 4 lay 3.7-fold (0.57 log units) above the measured number, and the stated range ends above it.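

In this assay, methoxy in place of hydrogen on an aromatic carbon gives a 3.9-fold lower number from compound 3 to compound 4 (0.60 log units; beyond the scatter), so the near-silent result on the core of compound 1 does not predict the result on the core of compound 3. Set side by side, the two steps differ, which shows that the entering group alone does not fix the size of this change in the series: the same change on two cores in this assay, a 1.0-fold higher number (0.01 log units; within the scatter) from compound 1 to compound 2 and a 3.9-fold lower number (0.60 log units; beyond the scatter) from compound 3 to compound 4, 4.1-fold (0.61 log units) apart, beyond the scatter of two such steps This comparison does not show what sets the gap, since it rests on two pairs only and the pairs differ both in core and in surroundings, the new methoxy in compound 4 being ortho to a methoxy group, meta to a methoxy group and para to a large group, and it gives no rule for any other core.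

Open, on these data alone, is whether the larger step belongs to the core of compound 3 or to that arrangement of groups on the ring, which the same addition at another aromatic carbon on each core would help to separate. Also open, as far as these compounds go, is whether an ethoxy group, a chlorine atom or an amine at the same place would follow the methoxy result on either core.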